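A few compounds are considered here, and "the series" means these few. Any claim that something is new, unique, unknown or untested is made for them only; others in the source may bear on it.

Measured so far:
- compound 1 `CCCCCCc1ccc(C(=O)CCN(C(C)C)C(C)C)cc1`: in an in vitro assay on BL21-DE3 cells for displacement of a labelled ligand from thyroid hormone receptor beta (Homo sapiens), read by fluorescence polarization (on this read-out lower numbers stand for stronger inhibition and higher numbers for weaker inhibition), compound 1 gives 2000 nM
- compound 2 `C=C(C)C(=O)c1ccc(CCCCCCC)cc1`: in this assay compound 2 gives 23200 nM

Compound 2 holds the highest of the two numbers recorded in this assay; its nearest neighbour is compound 1, whose number is lower by a gap that lies beyond the scatter of the method. For the measured compounds named here, no single-point step between the two measured compounds is available, so their two values can only be read side by side.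

The next compound, compound 3 `C=CC(=O)c1ccc(CCCCCCC)cc1`, is not yet measured. Its difference from compound 2 is hydrogen in place of methyl on a double-bonded chain carbon bound to a carbonyl carbon. Going by the values given here, with no comparable step, the direction of the change must be guessed from the two values alone. Given that compound 1 sits at 2000 nM and compound 2 at 23200 nM, the expectation for compound 3 is a number lower than that of compound 2, by a step of moderate size rather than none.

The estimated step from compound 2 to compound 3 in this assay is a 5.8-fold lower number from compound 2 to compound 3 (0.76 log units; beyond the scatter). Compound 3 is accordingly expected to give about 4000 nM in this assay, within a range from 1200 nM to 15000 nM.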

Compound 3, half-maximal inhibitory concentration: 10500 nM
Compound 3: middle estimate off by 2.6-fold (0.42 log units), on the low side; low and high end bracket the measured number.
By their numbers in this assay, from the lowest: compound 1; then compound 3; then compound 2.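

In this assay, for the compounds shown here, the exchange of methyl for hydrogen on a double-bonded chain carbon bound to a carbonyl carbon gives a 2.2-fold lower number from compound 2 to compound 3 (0.34 log units; beyond the scatter) and is the first single-place step available. This position therefore responds to a change as small as one carbon, although the step is modest, and the methyl is not required for a measurable number in this read-out. The vinylcarbonyl compound still gives a lower number than the (1-methylethenyl)carbonyl compound. The direction holds for this one pair only, and nothing measured here accounts for the step.

The compounds shown leave open whether the number keeps moving with other groups on this carbon, such as ethyl or phenyl, or whether a single methyl is a special case on an otherwise similar scale. Also open, as far as these compounds go, is how a saturated carbon chain in place of the double bond, or an amine or carboxylic acid added to the vinylcarbonyl unit, would read on the shared core, and whether a longer chain on that core would leave this step unchanged.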